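Swapping the amide's aryl substituent in an inactive antiproliferative series

This account rests on a few compounds, and the source may have more. Where it says the series, first, only, none or still open, it means among the compounds named here.

Compound 1 `COc1ccc(-c2cc(=O)c3c(OC)cc(OC)cc3n2S(=O)(=O)c2cc(Cl)cc(Cl)c2O)cc1`: in an ADME assay on BJ cells (Homo sapiens) for antiproliferative activity, with a stated time of 72 h (on this read-out lower numbers stand for an effect already at smaller amounts and higher numbers for an effect only at larger amounts of compound), compound 1 gives > 37900 nM, a limit of the assay.
Compound 2 `COc1ccc(-c2cc(=O)c3c(OC)cc(OC)cc3n2S(=O)(=O)c2c(C(C)C)cc(C(C)C)cc2C(C)C)cc1`: in this assay compound 2 gives > 341000 nM, again a limit.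
Compound 3 `COc1cc(OC)c2c(=O)cc(C(=O)Nc3ccc(N4CCN(C)CC4)cc3)[nH]c2c1`: in this assay compound 3 gives > 19800 nM, also a limit.

None of the three measured compounds returns a number in this assay; each reaches only a limit. For the measured compounds named here, compound 3 stands at the limit of > 19800 nM in this assay, at which 1 of the 3 values shown sits, and the other two values shown are likewise limits, at the limit of > 341000 nM in this assay, at which 1 of the 3 values shown sits, and (the limit of > 37900 nM in this assay, at which 1 of the 3 values shown sits), so no ordering among the three can be drawn and no measured step exists to lean on.

Compound 4 `COc1cc(OC)c2c(=O)cc(C(=O)Nc3ccc(S(=O)(=O)c4ccccc4)cc3)[nH]c2c1` differs from compound 3 in one place: phenylsulfonyl in place of 4-methylpiperazin-1-yl on an aromatic carbon, para to a large group. With every measured value a limit, there is no basis to expect a step beyond the usual scatter in either direction for this change. Compound 4 is therefore expected to remain without a measurable effect, with an estimate of 30000 nM and a range from 10000 nM to 100000 nM. The step this estimate means is expected to be a step that the limit leaves unreadable from compound 3 to compound 4, most likely reported again only as a limit.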

Compound 4, half-maximal effective concentration: > 70600 nM
Compound 4: a limit, no number; the forecaster's own chance of this, stated with the estimate: 80%; middle value at least 2.3-fold (0.37 log units) from the limit.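

In this assay compound 4 gives > 70600 nM, a limit of the assay and not a number. Compound 3 also reaches only a limit, so no step can be read between compound 3 and compound 4. The compounds shown leave open whether any of them has a measurable effect in this assay, and how phenylsulfonyl in place of 4-methylpiperazin-1-yl would shift it.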